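The compounds below may be only part of what the source reports. "The series", "measured", "known", "first", "only" and "open" are said of these compounds alone.

Measured compounds:
compound 1 `CN(C)C(=O)n1cc(C(=O)c2ccn3c2CSC3c2cccnc2)c2ccc(Cc3ccccc3)cc21`, 0.09 mg/kg
compound 2 `CN(C)C(=O)n1cc(C(=O)c2ccn3c2CSC3c2cccnc2)c2ccc(Sc3ccc(F)cc3)cc21`, 0.27 mg/kg
compound 3 `Cn1cc(C(=O)c2ccn3c2CSC3c2cccnc2)c2ccc(-c3ccc(F)cc3)cc21`, 0.09 mg/kg

In a functional assay on the whole organism for inhibition, with Rattus norvegicus as the target (on this read-out lower numbers stand for an effect already at smaller amounts and higher numbers for an effect only at larger amounts of compound), compound 3 gives 0.09 mg/kg, level with compound 1 at the digits shown and together with it the lowest of the three numbers; the only larger value is that of compound 2, which lies a step away that is beyond the scatter. Among the measured compounds shown here, the single measured step, a 3.0-fold higher number from compound 1 to compound 2 (0.48 log units; beyond the scatter), concerns the substituent on an aromatic carbon of the shared core and does not touch the aromatic nitrogen.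

Compound 4 `NNC(=O)n1cc(C(=O)c2ccn3c2CSC3c2cccnc2)c2ccc(-c3ccc(F)cc3)cc21` has not yet been measured. It differs from compound 3 at that nitrogen: aminocarbamoyl in place of methyl on an aromatic nitrogen. For the measured compounds named here, no measured pair changes this position alone. What the numbers do show is that compounds 1 and 2 carry a carbamoyl-type group on the same nitrogen while compound 3 carries methyl, and compound 1 and compound 3 sit at the same value; a carbonyl-bearing group at this nitrogen is thus not obviously harmful in this assay.

On this basis the change from compound 3 to compound 4 is expected to give a step of about a 1.3-fold higher number from compound 3 to compound 4 (0.12 log units; within the scatter), within the scatter or only slightly beyond it. Compound 4 is therefore estimated at 0.12 mg/kg, with a range from 0.04 mg/kg to 0.4 mg/kg.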

Compound 4, dose for half-maximal effect: 0.04 mg/kg
Estimate against measurement, compound 4: 3.0-fold (0.48 log units) above, within the range that was stated.
By their numbers in this assay, from the lowest: compound 4; then compounds 1 and 3 (each within the scatter of the next); then compound 2.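

In this assay, the change of methyl to aminocarbamoyl on the aromatic nitrogen gives a 2.3-fold lower number from compound 3 to compound 4 (0.35 log units; beyond the scatter), the first step measured at this position on its own. It shows that the number at this nitrogen depends on the group it carries, and that the step runs towards a lower number, modest in size but beyond the scatter, when aminocarbamoyl, with its hydrogen-bond donors and acceptors, replaces methyl, which has none. No measurement is available that would explain this step, so it stands as an observation only.

Whether the lower number needs the whole aminocarbamoyl group remains open, as the compounds shown do not separate its carbonyl from its terminal amine, and an acetyl group or a plain carbamoyl group on this nitrogen would be needed to tell these apart. Also open, going by these compounds, is whether the same change would give a similar step with the benzyl group of compound 1 or the (4-fluorophenyl)sulfanyl group of compound 2 on the aromatic carbon, since this single pair carries neither.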